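Swapping the aniline substituent on a shared thienopyrimidine-type core

This account rests on a few compounds, and the source may have more. Where it says the series, first, only, none or still open, it means among the compounds named here.

Measured so far:
- compound 1, `C#Cc1cccc(Nc2ncnc3sc(NC(=O)/C=C/c4ccccc4)cc23)c1`: 4640 nM
- compound 2, `N#Cc1cccc(Nc2ncnc3cc(NC(=O)/C=C/c4ccccc4)sc23)c1`: 7220 nM
- compound 3, `COc1ccc(/C=C/C(=O)Nc2cc3c(Nc4cc(Cl)cc(Cl)c4)ncnc3s2)cc1`: 43300 nM

Of the compounds shown here, three have been tested in a functional assay on HeLa cells (Homo sapiens) for antiproliferative activity, read by MTT assay, with a stated time of 48 h; a higher number here means a weaker inhibitor, a lower number a stronger inhibitor. Compound 1 has the lowest number of the three. Its nearest neighbour is compound 2, whose number is higher by an amount that falls within the usual scatter of repeated measurements, so the two cannot be ranked against each other. Compound 3, which differs from compound 1 in two places at once, gives a number that is higher than compound 1 by a margin beyond the scatter.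

The step from compound 1 leads to compound 4, `O=C(/C=C/c1ccccc1)Nc1cc2c(Nc3cccc(Cl)c3F)ncnc2s1`, which has not yet been measured. The change is 3-chloro-2-fluorophenyl in place of 3-ethynylphenyl on a nitrogen on an aromatic ring. Among the compounds with values here, no pair of measured compounds differs by this one change alone, so there is no measured step to lean on. Compound 3, which also carries a halogenated aniline, shows a clearly weaker result than compound 1, but it also carries a methoxy group on the cinnamamide, so its value cannot be attributed to either change.

Given this, compound 4 is expected to give a somewhat higher number than compound 1, with the step of a 1.9-fold higher number from compound 1 to compound 4 (0.29 log units; within the scatter) estimated to reach a little beyond the scatter. The estimate for compound 4 is 9000 nM, within a range from 3000 nM to 30000 nM.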

Compound 4, half-maximal inhibitory concentration: 34900 nM
Beside the measured number, compound 4's estimate is 3.9-fold (0.59 log units) below it; the measured number lies above the stated range.
By their numbers in this assay, from the lowest: compounds 1 and 2 (each within the scatter of the next); then compounds 4 and 3 (each within the scatter of the next).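

Within the data shown here, this is the first comparison here in which only the aniline substituent changes, so the shift in this assay, a 7.5-fold higher number from compound 1 to compound 4 (0.88 log units; beyond the scatter), can be assigned to this one place on the shared core. With the rest of the molecule held constant, 3-chloro-2-fluorophenyl gives a clearly weaker result than 3-ethynylphenyl, even though both groups have the same count of heavy atoms and one six-membered aromatic ring, so matching those counts does not preserve the activity. Nothing measured here explains the difference between the two groups.

This single step removes the ethynyl group and brings in chlorine and fluorine together, so it cannot show which part of the exchange matters; a phenyl ring carrying only the chlorine or only the fluorine would separate them. It also leaves open how a ring bearing an amine or a carboxylic acid would read at this place on the nitrogen, and whether a plain unsubstituted phenyl would sit closer to compound 1 or to compound 4.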